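Swapping an Aryl Ether for an Aryl Thioether

This account rests on a few compounds, and the source may have more. Where it says the series, first, only, none or still open, it means among the compounds named here.

Compound 1 `Nc1cc(N)c2nc(-c3ccccc3)c(Oc3ccc(Cl)c(Cl)c3)nc2c1` belongs to a small set examined in a functional assay on OVCAR-8 cells (Homo sapiens) for inhibition, read by sulforhodamine B assay, with a stated time of 48 h; a higher number here means that more compound is tolerated, a lower number that less compound is tolerated. In this assay compound 1 gives < 100000 nM, and that reading is a limit of the assay rather than a measured number (the limit of < 100000 nM in this assay, at which 1 of the 2 values shown sits). Compound 2 `COc1cc(CNc2nc3cc(N)cc(N)c3nc2-c2ccccc2)cc(OC)c1OC` carries a different group at the same part of the shared core, and in this assay compound 2 gives 31600 nM. Within the data shown here, no pair of measured compounds differs in only one place, so no single-change step is available to calibrate expectations; the two readings simply show that both compounds sit in the weak range of this assay.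

Compound 3 `COc1ccc(Sc2nc3cc(N)cc(N)c3nc2-c2ccccc2)cc1` has not yet been measured. Relative to compound 1 the change is (4-methoxyphenyl)sulfanyl in place of 3,4-dichlorophenoxy on an aromatic carbon. With compound 1 known only as a limit, the step from compound 1 to compound 3 is expected to be a step that the limit leaves unreadable from compound 1 to compound 3, which cannot be placed in either direction beyond the scatter. Compound 3 is therefore estimated at 30000 nM, with a plausible range from 8000 nM to 100000 nM.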

Compound 3, concentration lethal to 50% of the cells: < 100000 nM
Compound 3 ended at the assay's limit; the forecaster's own chance of this, stated with the estimate: 30%; the middle value is on the limit's open side.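

In this assay compound 3 gives < 100000 nM, which is a limit of the assay and not a number. Among these compounds, compound 1 stands at the same kind of limit, so no step between compound 1 and compound 3 can be read: the limit of < 100000 nM in this assay, at which 2 of the 3 values shown sit. The compounds shown leave open whether (4-methoxyphenyl)sulfanyl in place of 3,4-dichlorophenoxy changes the reading at all.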